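Swapping a bromo for a chloro on the shared core

The source may hold more compounds than are shown below. What is called first, only, known or untested is meant among the compounds shown, and "the series" means these compounds.

Of the compounds shown here, two share a common core and have been tested in a functional assay on MDA-MB-468 cells (Homo sapiens) for cytotoxicity, read by sulforhodamine B assay, with a stated time of 48 h; a higher number here means a weaker inhibitor of growth, a lower number a stronger inhibitor of growth. Compound 1 `CN(C)CN1C(=O)C(=O)c2c(Br)cccc21` carries a bromo on an aromatic carbon; in this assay compound 1 gives 49000 nM. Compound 2 `CN(C)CN1C(=O)C(=O)c2ccccc21` has a hydrogen at that position, and in this assay compound 2 gives 50200 nM. Of these two numbers compound 2 holds the higher one, but the difference a 1.0-fold higher number from compound 1 to compound 2 (0.01 log units; within the scatter) is within the scatter, so the two compounds cannot be told apart here. Compound 3 `CN(C)CN1C(=O)C(=O)c2c(Cl)cccc21` is compound 2 with chloro in place of hydrogen on an aromatic carbon. For the measured compounds named here, the only step that bears on this change is the one from compound 1 to compound 2, where removing a bromo at the same place left the number essentially unchanged. A halogen of a different size at the same aromatic carbon is therefore expected to give at most a step within the scatter, a 1.0-fold lower number from compound 2 to compound 3 (0.00 log units; within the scatter). For compound 3 the estimated value in this assay is 50000 nM, with a likely range from 25000 nM to 100000 nM.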

Compound 3, concentration for 50% growth inhibition: 107000 nM
Beside the measured number, compound 3's estimate is 2.1-fold (0.33 log units) below it; the whole stated range lies below it.
By their numbers in this assay, from the lowest: compounds 1 and 2 (each within the scatter of the next); then compound 3.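

This aromatic carbon does respond to what sits on it, since in this assay the chloro brings a modest weakening of growth inhibition, a 2.1-fold higher number from compound 2 to compound 3 (0.33 log units; beyond the scatter), although compound 1 and compound 2 could not be told apart. The two halogens also differ from each other, with a 2.2-fold higher number from compound 1 to compound 3 (0.34 log units; beyond the scatter), so one halogen cannot be assumed to stand in for the other at this place. Nothing measured on these compounds offers an explanation for the gap between chloro and bromo.

From the compounds shown here alone, it remains open how a fluoro, a methyl or a methoxy at the same aromatic carbon would compare with chloro and bromo. Going by these compounds, it is also open whether the chloro step would persist if a morpholine replaced the dimethylamino group on the shared core.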